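This account rests on a few compounds, and the source may have more. Where it says the series, first, only, none or still open, it means among the compounds named here.

Within the data shown here, compound 2, with the structure `COC(=O)COc1cccc(C2C(C(=O)OC)=C(C)NC(C)=C2C(=O)OC)c1`, gives 10000 nM in an assay on cells for inhibition of Voltage-gated L-type calcium channel (Rattus norvegicus), read by fluorescence and calcium flux, with stated times of 30 min and 2 min (on this read-out lower numbers stand for stronger inhibition and higher numbers for weaker inhibition), the highest of the two numbers measured so far. Its nearest neighbour, compound 1 with the structure `COC(=O)C1=C(C)NC(C)=C(C(=O)OC)C1c1cccc(OCC(=O)N2CCCC2)c1`, gives 3600 nM. Among the measured compounds shown here, the one step connecting them, a 2.8-fold higher number from compound 1 to compound 2 (0.44 log units; beyond the scatter), shows that the pyrrolidin-1-yl amide carries a lower number than the methyl ester. Compound 3, with the structure `COC(=O)C1=C(C)NC(C)=C(C(=O)OC)C1c1cccc(OCC(=O)N2CCCCC2)c1`, departs from compound 2 by piperidin-1-yl in place of methoxy on a carbonyl carbon. The step from compound 1 to compound 2 bears directly on this change, run in reverse with a six-membered rather than a five-membered ring entering on the carbonyl carbon. A lower number of a similar size is therefore expected, the estimated step being a 2.9-fold lower number from compound 2 to compound 3 (0.46 log units; beyond the scatter). Compound 3 is expected to give about 3500 nM in this assay, within a range from 1400 nM to 9000 nM.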

Compound 3, half-maximal inhibitory concentration: 10000 nM
Compound 3: middle estimate off by 2.9-fold (0.46 log units), on the low side, and the stated range ends below it.
By their numbers in this assay, from the lowest: compound 1; then compounds 2 and 3 (each within the scatter of the next).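

In this assay, piperidin-1-yl in place of methoxy on the carbonyl carbon brings no change at the digits printed from compound 2 to compound 3 (within the scatter) and so does not repeat the difference seen between the pyrrolidin-1-yl amide and the methyl ester. The two amides themselves now differ, with a 2.8-fold higher number from compound 1 to compound 3 (0.44 log units; beyond the scatter) as the only change is piperidin-1-yl in place of pyrrolidin-1-yl, so a ring-bearing amide at this place does not by itself go with the lower number, and among these three compounds only compound 1 stands apart. Nothing available gives a reason for this difference between the two amides.

As far as these compounds go, whether the lower number belongs to pyrrolidin-1-yl alone remains open, since no other amine, such as azetidin-1-yl, morpholin-4-yl or diethylamino, appears on this carbonyl carbon. Also open, from the compounds shown here alone, is how a carboxylic acid at this place, or a longer chain leading to the carbonyl, would read out.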